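The source may report more compounds than this note shows. Statements on the series, on what has been measured and on what is new or still open speak of the compounds shown alone.

Measured so far in a functional assay on BaF3 cells (Mus musculus) for antiproliferative activity, with a stated time of 48 h; a lower number here means a stronger inhibitor, a higher number a weaker inhibitor:

- Compound 1, `CC(=O)N1CCN([C@H]2C[C@@H](n3cc(-c4ccccc4O)c4c(N)ncnc43)C2)CC1`: > 10000 nM
- Compound 2, `CC(=O)N1CCN([C@H]2C[C@@H](n3cc(-c4ccc(O)cc4)c4c(N)ncnc43)C2)CC1`: > 10000 nM

For compound 2, > 10000 nM is a limit and not a number. Compound 1 gives a limit too, so both stand at the same mark: the limit of > 10000 nM in this assay, at which 2 of the 2 values shown sit. Going by the values given here, the only measured step is a step that the two limits leave unreadable from compound 1 to compound 2, so it offers no size to carry forward.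

Compound 3, `CC(=O)N1CCN([C@H]2C[C@@H](n3cc(-c4cc(O)ccc4F)c4c(N)ncnc43)C2)CC1`, keeps the shared core and changes the same aryl group: 2-fluoro-5-hydroxyphenyl in place of 4-hydroxyphenyl on an aromatic carbon, (2-fluoro-5-hydroxyphenyl in place of 4-hydroxyphenyl on an aromatic carbon). With no readable step as a guide, this is a loose expectation. Another limit is about as likely as a number, and any number would have to be lower, meaning a stronger inhibitor in this assay. The estimated change is an at least 2.5-fold lower number from compound 2 to compound 3 (0.39 log units; beyond the scatter). For compound 3 the expected value is 4000 nM, with an estimated range of 400 nM to 10000 nM.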

Compound 3, half-maximal inhibitory concentration: > 10000 nM
Compound 3: no number, only a limit (the forecaster's own chance of this, stated with the estimate: 50%); middle value at least 2.5-fold (0.39 log units) from the limit.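

In this assay compound 3 gives > 10000 nM, which is a limit and not a number. Going by these compounds alone, no step among compound 1, compound 2 and compound 3 can be read: the limit of > 10000 nM in this assay, at which 3 of the 3 values shown sit. These compounds leave open whether any aryl group at this place gives a measurable value.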